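Benzyl for allyl on a galloyl cysteine ester

A few compounds are considered here, and "the series" means these few. Any claim that something is new, unique, unknown or untested is made for them only; others in the source may bear on it.

Of the compounds shown here, two measured so far share a core in which a methyl ester and a sulfur-linked side chain hang from the same carbon, with an aromatic amide attached. Compound 1 `COC(=O)[C@H](CSCc1ccccc1)NC(=O)c1cc(OC)c(OC)c(OC)c1` carries a benzylsulfanyl chain and three methoxy groups on the amide ring. In an assay on RAW264.7 cells for antagonist activity at Toll-like receptor 2 (Mus musculus), read by Griess assay, with a stated time of 24 h (a lower number here means a stronger inhibitor, a higher number a weaker inhibitor), compound 1 gives 32700 nM. Compound 2 `C=CCSC[C@H](NC(=O)c1cc(O)c(O)c(O)c1)C(=O)OC` carries an allylsulfanyl chain and three hydroxyl groups instead of the methoxy groups, and in this assay compound 2 gives 52100 nM. Compound 2 has the highest of the two numbers, but its gap to compound 1 is within the scatter, so the two stand level.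

Compound 3 `COC(=O)[C@H](CSCc1ccccc1)NC(=O)c1cc(O)c(O)c(O)c1` differs from compound 2 in one place: phenyl in place of vinyl on a saturated chain carbon bound to a sulfur. Among the measured compounds shown here, no measured pair isolates this change, so any expectation is loose. For the measured compounds named here, the only anchor is that compound 1, which carries the same benzylsulfanyl chain, sits at 32700 nM, within the scatter of compound 2. The step of a 1.5-fold lower number from compound 2 to compound 3 (0.17 log units; within the scatter) is therefore expected to be small, leaning toward a slightly lower number but not clearly beyond the scatter. Compound 3 is expected to give about 35000 nM, with a range from 15000 nM to 80000 nM.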

Compound 3, half-maximal inhibitory concentration: 60700 nM
The estimate for compound 3 lay 1.7-fold (0.24 log units) below the measured number; the measured number falls inside the stated range.
By their numbers in this assay, from the lowest: compounds 1, 2 and 3 (each within the scatter of the next).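

Among the compounds shown here, compound 2 and compound 3 are the first pair here that differ in one place only, so the chain on sulfur can now be read on its own, with the three hydroxyl groups on the amide ring left unchanged. In this assay, phenyl in place of vinyl on a saturated chain carbon bound to a sulfur gives a 1.2-fold higher number from compound 2 to compound 3 (0.07 log units; within the scatter). A six-membered aromatic ring of carbon thus enters where a vinyl group leaves, and the number does not move beyond the usual spread of repeated measurements, so allylsulfanyl and benzylsulfanyl stand level on this core. No further measurement bears on why this swap leaves the number level.

Going by these compounds, with only these two chains compared, it remains open whether any group at this place can move the number beyond the scatter, for instance a chain ending in an amine or a carboxylic acid, or a longer chain. For the compounds shown here, the single step also cannot tell whether the same swap would stay level on a different amide ring.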